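The source may report more compounds than this note shows. Statements on the series, on what has been measured and on what is new or still open speak of the compounds shown alone.

Compound 1 `CCOC(=O)CN(C)C(=O)c1ccc(C(CC)(CC)c2ccc(OCC(O)C(C)(C)C)c(C)c2)n1CC` carries the shared core with an amide-type nitrogen attached to its carbonyl carbon. In a functional assay on HepG2 cells (Homo sapiens), read by MTT assay, with a stated time of 48 h (a higher number here means a weaker inhibitor, a lower number a stronger inhibitor), compound 1 gives > 50000 nM, which is a limit of the assay and not a number. Compound 2 `C=CCN(C)C(=O)c1ccc(C(CC)(CC)c2ccc(OCC(O)C(C)(C)C)c(C)c2)n1CC` is its closest measured neighbour, with a vinyl in place of the ethoxycarbonyl on the saturated chain carbon bound to that nitrogen. In this assay compound 2 gives > 50000 nM, again a limit rather than a number. The step that the two limits leave unreadable from compound 1 to compound 2 therefore cannot be read in size, and the limit of > 50000 nM in this assay, at which 2 of the 2 values shown sit, is all that the two measured values show.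

Compound 3 `CCn1c(C(=O)Oc2ccc(CCO)cc2)ccc1C(CC)(CC)c1ccc(OCC(O)C(C)(C)C)c(C)c1` differs from compound 1 by a group of 10 heavy atoms (8 carbon, 2 oxygen; one six-membered aromatic ring of carbon only) in place of a group of 8 heavy atoms (5 carbon, 1 nitrogen, 2 oxygen; no ring), on a carbonyl carbon. Within the data shown here, no measured step bears directly on this change at the carbonyl carbon; the one step that exists, a step that the two limits leave unreadable from compound 1 to compound 2, touches only the chain on the amide-type nitrogen and has no readable size. With compound 1 standing only at a limit, the expectation for compound 3 is that it too sits at or near that limit, so the step that the limit leaves unreadable from compound 1 to compound 3 is expected to remain unreadable. Compound 3 is estimated at 60000 nM, between 20000 nM and 200000 nM.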

Compound 3, half-maximal inhibitory concentration: > 50000 nM
Compound 3 was reported as a limit; the forecaster's own chance of this, stated with the estimate: 80%; the middle value is on the limit's open side.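

Compound 3 joins compound 1 and compound 2 at a limit of the assay, so no step among these three compounds can be read in size: the limit of > 50000 nM in this assay, at which 3 of the 3 values shown sit. What the compounds shown leave open is how strongly each one actually acts in this assay and whether any change at the carbonyl carbon alters that.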